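This account rests on a few compounds, and the source may have more. Where it says the series, first, only, none or still open, it means among the compounds named here.

Measured so far:
compound 1, `C=CCN1[C@H](c2ccccc2)C(C(=O)OC)C(=O)C(C(=O)OC)[C@@H]1c1ccccc1`: > 100 uM
compound 2, `COC(=O)C1=C(O)C[C@H](c2ccccn2)N(Cc2ccc(OC)cc2)[C@@H]1c1ccccn1`: 29.9 uM

In an ADME assay on J774.1 cells (Mus musculus) for cytotoxicity, with a stated time of 48 h (a higher number here means that more compound is needed for the effect, a lower number that less compound is needed), compound 1 reaches only a limit, > 100 uM, and gives no number. In this assay, going by the values given here, compound 2 gives 29.9 uM, the only number so far. The other value shown is a limit, (the limit of > 100 uM in this assay, at which 1 of the 2 values shown sits). Compound 3, `COC(=O)C1=C(O)C[C@H](c2ccccn2)N(Cc2ccccc2)[C@@H]1c1ccccn1`, is yet to be measured. It differs from compound 2 by hydrogen in place of methoxy on an aromatic carbon. Among the compounds with values here, no step between measured compounds is available to set a size against, and this change is expected to move this assay by no more than the scatter, in either direction. Compound 3 is estimated at 35 uM, within 15 uM to 80 uM. The expected step is a 1.2-fold higher number from compound 2 to compound 3 (0.07 log units; within the scatter).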

Compound 3, concentration for half-maximal effect: 33.2 uM
Compound 3: middle estimate off by 1.1-fold (0.02 log units), on the high side; the measured number falls inside the stated range.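

In this assay, going by these compounds alone, the change from 4-methoxybenzyl to benzyl gives a 1.1-fold higher number from compound 2 to compound 3 (0.05 log units; within the scatter), the first comparison here of two compounds that differ in one place. On this aromatic ring, then, hydrogen can stand in place of methoxy without a change in cytotoxicity that rises above the scatter. Nothing shown gives a reason for this result.

On these data alone, whether an amine, a carboxylic acid or a longer chain such as butoxy at this place would also leave the number unchanged stays open. This single pair also cannot tell whether the same change would behave alike on another core.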